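The compounds below may be only part of what the source reports. "The series", "measured", "known", "first", "only" and "open" are said of these compounds alone.

For the measured compounds named here, compound 2, whose structure is `COc1cc(Cc2nc3c(N)ncnc3n2CCCCCO)cc(OC)c1OC`, is one of only two measured compounds in this set. In a functional assay on MCF7 cells (Homo sapiens) for cytotoxicity (on this read-out higher numbers stand for an effect only at larger amounts of compound and lower numbers for an effect already at smaller amounts), compound 2 gives 84900000 nM. Going by the values given here, compound 1, with the structure `COc1cc(Cc2nc3c(N)ncnc3n2CCCCO)cc(OC)c1OC`, gives 76900000 nM in this assay, so the two numbers lie within the scatter of each other; the only measured step, a 1.1-fold higher number from compound 1 to compound 2 (0.04 log units; within the scatter), is accordingly small. Compound 3, whose structure is `COc1cc(Cc2nc3c(N)ncnc3n2CC(C)CCCO)cc(OC)c1OC`, differs from compound 2 by methyl in place of hydrogen on a saturated chain carbon bound to two saturated chain carbons. Among the compounds with values here, no measured step in this set touches the same place, and the single step available, from compound 1 to compound 2, concerns the chain length rather than a branch; it gives no reason to expect movement beyond the scatter. The step from compound 2 to compound 3 in this assay is therefore estimated at a 1.0-fold higher number from compound 2 to compound 3 (0.00 log units; within the scatter). Compound 3 is expected to give about 85000000 nM, with a range from 40000000 nM to 180000000 nM.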

Compound 3, half-maximal effective concentration: 8770000 nM
Compound 3: middle estimate off by 9.7-fold (0.99 log units), on the high side, outside the stated range (below it).
By their numbers in this assay, from the lowest: compound 3; then compounds 1 and 2 (each within the scatter of the next).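

Methyl in place of hydrogen on a saturated chain carbon bound to two saturated chain carbons shifts the number in this assay beyond the scatter (a 9.7-fold lower number from compound 2 to compound 3 (0.99 log units; beyond the scatter)), whereas hydroxymethyl in place of hydroxy had left it within the scatter (a 1.1-fold higher number from compound 1 to compound 2 (0.04 log units; within the scatter)). For the compounds shown here, the chain therefore responds to a branch in a way that the only earlier step did not reveal, and the change from 3-hydroxypropyl to 4-hydroxy-1-methylbutyl also lies beyond the scatter (an 8.8-fold lower number from compound 1 to compound 3 (0.94 log units; beyond the scatter)). No measurement available here accounts for this shift.

From the compounds shown here alone, it remains open whether ethyl or an amine at this same carbon would give a lower or higher number than methyl. Going by these compounds, it is also open whether a longer chain carrying the same methyl would keep the lower number.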